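A few compounds are considered here, and "the series" means these few. Any claim that something is new, unique, unknown or untested is made for them only; others in the source may bear on it.

Measured compounds in an ADME assay for permeability, using PAMPA, with a stated time of 4 h; a higher number here means that the compound crosses the layer faster, a lower number that the compound crosses the layer more slowly:
Compound 1 `Cn1c(COc2cccc(C(=O)O)c2)nc2ccc(Oc3ccc(Cl)c(F)c3)nc21` gives 25.6 10^-6 cm/s.
Compound 2 `Cc1ccc(Oc2ccc3nc(COc4cccc(C(=O)O)c4)n(C)c3n2)cc1C` gives 12.4 10^-6 cm/s.
Compound 3 `Cn1c(COc2cccc(C(=O)O)c2)nc2ccc(Oc3ccc(Cl)cn3)cc21` gives 16.2 10^-6 cm/s.

Compound 3 stands second highest of the three numbers; its gaps to compound 2 and to compound 1 both lie within the scatter, so no order among the three is claimed. Compound 4 `Cc1ccc(Oc2ccc3nc(COc4cccc(C(=O)O)c4)n(C)c3c2)nc1C` is not yet measured and differs from compound 3 by 5,6-dimethylpyridin-2-yl in place of 5-chloropyridin-2-yl on an oxygen on an aromatic ring. Going by the values given here, the one measured step that bears on this is a 2.1-fold lower number from compound 1 to compound 2 (0.31 log units; beyond the scatter), a chloro-to-dimethyl exchange on an oxygen on an aromatic ring, though on a different core. A single step is thin ground, but a modest fall of similar size is therefore expected, a 1.8-fold lower number from compound 3 to compound 4 (0.26 log units; within the scatter). Compound 4 is expected to give 9 10^-6 cm/s, with a range of 5 10^-6 cm/s to 16 10^-6 cm/s.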

Compound 4, apparent permeability: 7.7 10^-6 cm/s
Compound 4: the middle estimate sits 1.2-fold (0.07 log units) above what was measured; the range from low to high includes it.
By their numbers in this assay, from the lowest: compounds 4, 2, 3 and 1 (each within the scatter of the next, the first and the last beyond it).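

In this assay, 5,6-dimethylpyridin-2-yl in place of 5-chloropyridin-2-yl gives a 2.1-fold lower number from compound 3 to compound 4 (0.32 log units; beyond the scatter), so a fall beyond the scatter also appears with this pyridine pair on the core of compound 3. Together with a 2.1-fold lower number from compound 1 to compound 2 (0.31 log units; beyond the scatter), that makes two pairs on different cores in which methyl groups replace a chloro-bearing group and the number falls, and no pair shown goes against this. No measured evidence bears on the origin of either step. Open, going by these compounds, is which of the two methyl groups, or the loss of chlorine, carries the step. Also open, on these data alone, is how a nitrile or an amine at this ring would read.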